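The source may hold more compounds than are shown below. What is called first, only, known or untested is meant among the compounds shown, and "the series" means these compounds.

Compound 1 `N#Cc1ncn(-c2ccc(F)cc2)c1/N=C/c1ccc([N+](=O)[O-])cc1`: 15900 nM
Compound 2 `COc1ccc(/C=N/c2c(C#N)ncn2-c2ccc(F)cc2)cc1OC`: 7230 nM

In a functional assay on T47D cells (Homo sapiens) for antiproliferative activity, read by MTT assay, with a stated time of 48 h (on this read-out lower numbers stand for stronger inhibition and higher numbers for weaker inhibition), compound 1 gives 15900 nM, the highest of the two numbers and so the weaker result. Compound 2 lies lower at 7230 nM, a gap just beyond the usual scatter.

Compound 3 `CC(C)c1ccc(/C=N/c2c(C#N)ncn2-c2ccc(F)cc2)cc1` keeps the core of compound 1 and changes one group: isopropyl in place of nitro on an aromatic carbon. This places isopropyl in place of nitro on an aromatic carbon, para to a large group. For the measured compounds named here, no measured pair shows this change on its own, so any forecast is uncertain. Compound 2 also lacks the nitro and gives 7230 nM, which offers modest support for a lower number. A small fall in this assay is therefore expected, with the estimated step being a 1.8-fold lower number from compound 1 to compound 3 (0.25 log units; within the scatter). The estimate for compound 3 is 9000 nM, with an expected range of 3000 nM to 25000 nM.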

Compound 3, half-maximal inhibitory concentration: > 25000 nM
Compound 3 gave a limit, no number (the forecaster's own chance of this, stated with the estimate: 5%); middle value at least 2.7-fold (0.44 log units) from the limit.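

In this assay compound 3 gives only a limit and not a number, > 25000 nM. Placing isopropyl in place of nitro on this aromatic carbon, para to a large group, gives an at least 1.5-fold higher number from compound 1 to compound 3 (0.19 log units; that floor lies within the scatter). This is the first direct reading of the change, and it shows that removing the nitro does not by itself deliver a lower number at this position, while the real size of the step stays unknown: the limit of > 25000 nM in this assay, at which 1 of the 3 values shown sits.

Going by these compounds, whether an amine, a carboxylic acid or a longer chain on the same carbon would give a lower number than the nitro of compound 1 remains open. Also open, on these data alone, is whether a group with no nitrogen or oxygen, such as chloro or a plain methyl, would behave like isopropyl here.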